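The source may report more compounds than this note shows. Statements on the series, on what has been measured and on what is new or still open speak of the compounds shown alone.

Measured compounds:
compound 1, `COc1c(OCCCN2CCCC2)cc2oc(-c3ccccc3)cc(=O)c2c1O`, 26600 nM
compound 2, `COc1c(OCCCN2CCCCC2)cc2oc(-c3ccccc3)cc(=O)c2c1O`, 22100 nM
compound 3, `COc1c(OCCCCN2CCCC2)cc2oc(-c3ccccc3)cc(=O)c2c1O`, 1400 nM

In a functional assay on HCT-116 cells (Homo sapiens) for antiproliferative activity, read by MTT assay, with a stated time of 48 h (a lower number here means a stronger inhibitor, a higher number a weaker inhibitor), compound 1 gives 26600 nM and compound 2 gives 22100 nM. The two differ only by piperidin-1-yl in place of pyrrolidin-1-yl on a saturated chain carbon, three bonds along the chain from an oxygen on an aromatic ring, and the step of a 1.2-fold lower number from compound 1 to compound 2 (0.08 log units; within the scatter) lies within the scatter. Relative to compound 1, the change is (pyrrolidin-1-yl)methyl in place of pyrrolidin-1-yl on a saturated chain carbon, three bonds along the chain from an oxygen on an aromatic ring for compound 3. In this assay compound 3 gives 1400 nM, so the step of a 19-fold lower number from compound 1 to compound 3 (1.28 log units; beyond the scatter) is large, as is a 16-fold lower number from compound 2 to compound 3 (1.20 log units; beyond the scatter).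

Compound 4, `COc1c(OCCCCN2CCCCC2)cc2oc(-c3ccccc3)cc(=O)c2c1O`, has not yet been measured in this assay. It differs from compound 3 by piperidin-1-yl in place of pyrrolidin-1-yl on a saturated chain carbon, four bonds along the chain from an oxygen on an aromatic ring. Going by the values given here, this is the same kind of change as the one from compound 1 to compound 2, but it is placed four bonds along the chain from the aromatic oxygen rather than three, so it is not the same change. Since the earlier step of a 1.2-fold lower number from compound 1 to compound 2 (0.08 log units; within the scatter) was within the scatter, compound 4 is expected to sit close to compound 3, with an estimated step of a 1.2-fold lower number from compound 3 to compound 4 (0.07 log units; within the scatter). The estimate for compound 4 in this assay is 1200 nM, expected between 500 nM and 3500 nM.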

Compound 4, half-maximal inhibitory concentration: 3000 nM
Compound 4: middle estimate off by 2.5-fold (0.40 log units), on the low side; low and high end bracket the measured number.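

In this assay, going by these compounds alone, piperidin-1-yl in place of pyrrolidin-1-yl four bonds along the chain gives a 2.1-fold higher number from compound 3 to compound 4 (0.33 log units; beyond the scatter) and this step cannot be told apart from the one for the same change three bonds along the chain: the same change on two cores in this assay, a 1.2-fold lower number (0.08 log units; within the scatter) from compound 1 to compound 2 and a 2.1-fold higher number (0.33 log units; beyond the scatter) from compound 3 to compound 4, 2.6-fold (0.41 log units) apart, within the scatter of two such steps. The change thus carries across these two cores without a difference that the data can resolve, while the longer chain still gives lower numbers when piperidin-1-yl is compared with either group on the shorter chain, with a 7.4-fold lower number from compound 2 to compound 4 (0.87 log units; beyond the scatter) and an 8.9-fold lower number from compound 1 to compound 4 (0.95 log units; beyond the scatter). Within the data shown here, this rests on only two pairs in one cell assay, so it does not show that the change would behave alike on any other core, and it gives no explanation for either step.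

The compounds shown leave open whether the same change would hold on a longer chain such as a five-carbon one. They also leave open how morpholin-4-yl or dimethylamino at the chain end would compare.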